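A few compounds are considered here, and "the series" means these few. Any claim that something is new, unique, unknown or untested is made for them only; others in the source may bear on it.

Compound 1 `Cc1cc(Cl)ccc1NC(=O)Nc1nc(Nc2ccccc2)cc(Sc2c[nH]c3ccccc23)n1` and compound 2 `Cc1cc(Cl)ccc1NC(=O)Nc1nc(Sc2c[nH]c3ccccc23)cc(N2CCCC2)n1` share one core and differ in a single group. In a functional assay on A549 cells (Homo sapiens) for inhibition, with a stated time of 72 h (on this read-out higher numbers stand for weaker inhibition and lower numbers for stronger inhibition), compound 1 reaches only a limit, > 50000 nM. Among the compounds with values here, compound 2 gives 8930 nM in this assay, the only true number here. Within the data shown here, their single change produced an at least 5.5-fold lower number from compound 1 to compound 2 (0.74 log units; beyond the scatter). Compound 3 `Cc1cc(Cl)ccc1NC(=O)Nc1nc(NC2CC2)cc(Sc2c[nH]c3ccccc23)n1` differs from compound 2 in one place: cyclopropylamino in place of pyrrolidin-1-yl on an aromatic carbon. Among the measured compounds shown here, only that one measured step bears on this change, and it swapped a different pair of groups, so no clear direction follows from it. The expected step is small, a 1.3-fold higher number from compound 2 to compound 3 (0.13 log units; within the scatter), within the usual scatter. Compound 3 is estimated at 12000 nM, with a range from 4000 nM to 40000 nM.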

Compound 3, half-maximal inhibitory concentration: 31500 nM
Estimate against measurement, compound 3: 2.6-fold (0.42 log units) below; low and high end bracket the measured number.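

Replacing pyrrolidin-1-yl with cyclopropylamino gives a 3.5-fold higher number from compound 2 to compound 3 (0.55 log units; beyond the scatter) in this assay, so compound 2 remains the strongest of the three and a second small amine does not match it. Replacing phenyl with cyclopropyl on the nitrogen gives an at least 1.5-fold lower number from compound 1 to compound 3 (0.20 log units; that floor lies within the scatter), and no order follows for that pair because the anilino value is a limit: the limit of > 50000 nM in this assay, at which 1 of the 3 values shown sits.

The pyrrolidin-1-yl and cyclopropylamino groups differ in both ring size and hydrogen-bond donors, and these compounds cannot separate the two. From the compounds shown here alone, it also remains open how a piperidine, a morpholine or an open-chain dimethylamino group would compare with compound 2.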